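Thiophen-3-yl in Place of 1,3-Thiazol-2-yl: Cytotoxicity

The compounds below may be only part of what the source reports. "The series", "measured", "known", "first", "only" and "open" are said of these compounds alone.

Of the compounds shown here, three sharing one core have been tested in an ADME assay on MT4 cells (Homo sapiens) for cytotoxicity; on this read-out lower numbers stand for higher toxicity in this test and higher numbers for lower toxicity in this test. Compound 1 `COC(=O)N[C@H](C(=O)NN(CCC[C@@](O)(Cc1ccccc1)C(=O)N[C@H]1c2ccccc2C[C@H]1O)Cc1ccc(N(C)C)cc1)C(C)(C)C` carries a dimethylamino group on its outer aromatic ring; in this assay compound 1 gives > 10000 nM, which is a limit of the assay and not a number. Compound 2 `COC(=O)N[C@H](C(=O)NN(CCC[C@@](O)(Cc1ccccc1)C(=O)N[C@H]1c2ccccc2C[C@H]1O)Cc1ccc(-c2ccccn2)cc1)C(C)(C)C` carries pyridin-2-yl instead; compound 2 gives > 10000 nM, again a limit. Compound 3 `COC(=O)N[C@H](C(=O)NN(CCC[C@@](O)(Cc1ccccc1)C(=O)N[C@H]1c2ccccc2C[C@H]1O)Cc1ccc(-c2nccs2)cc1)C(C)(C)C` carries 1,3-thiazol-2-yl; compound 3 gives > 10000 nM, also a limit. Compound 3 therefore stands where both neighbours stand, at the limit, as the limit of > 10000 nM in this assay, at which 3 of the 3 values shown sit, shows. The steps a step that the two limits leave unreadable from compound 1 to compound 2, a step that the two limits leave unreadable from compound 1 to compound 3 and a step that the two limits leave unreadable from compound 2 to compound 3 cannot be sized, since all values are limits.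

Compound 4 `COC(=O)N[C@H](C(=O)NN(CCC[C@@](O)(Cc1ccccc1)C(=O)N[C@H]1c2ccccc2C[C@H]1O)Cc1ccc(-c2ccsc2)cc1)C(C)(C)C` is not yet measured. It differs from compound 3 by thiophen-3-yl in place of 1,3-thiazol-2-yl on an aromatic carbon. Every change tried so far left the read-out at the limit, so no step beyond the scatter is expected here either. Compound 4 is expected to give about 15000 nM in this assay, within 8000 nM to 40000 nM, most likely again only as a limit. The estimated step from compound 3 to compound 4 is a step that the limit leaves unreadable from compound 3 to compound 4.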

Compound 4, half-maximal cytotoxic concentration: > 10000 nM
Compound 4 was reported as a limit; the forecaster's own chance of this, stated with the estimate: 85%; the middle value lies beyond the limit too.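

In this assay compound 4 gives > 10000 nM, which is a limit and not a number, so its steps from compound 1, compound 2 and compound 3 cannot be read. The compounds shown leave open how these four compounds rank, and whether any outer group on the shared core gives a readable cytotoxic concentration.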